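Amidine benzamides at serine protease 1: a pyridyl swap

The compounds below may be only part of what the source reports. "The series", "measured", "known", "first", "only" and "open" are said of these compounds alone.

Measured compounds:
compound 1, `N=C(N)c1cccc(C(=O)NC(C(=O)NCC2CCC(CN)CC2)c2cccc3ccccc23)c1`, 2100 nM
compound 2, `N=C(N)c1cccc(C(=O)N[C@@H](C(=O)N2CCN(c3ccc(F)cc3)CC2)c2ccccc2)c1`, 1260 nM
compound 3, `CSCC[C@@H](NC(=O)c1cccc(C(=N)N)c1)C(=O)NCC1CCC(CN)CC1`, 10000 nM

Of the compounds shown here, three sharing an amidine benzamide core have been measured in an assay on isolated protein for binding affinity to serine protease 1 (Homo sapiens); on this read-out lower numbers stand for stronger inhibition and higher numbers for weaker inhibition. Compound 2, `N=C(N)c1cccc(C(=O)N[C@@H](C(=O)N2CCN(c3ccc(F)cc3)CC2)c2ccccc2)c1`, gives 1260 nM, the lowest number of the three. Compound 1 gives 2100 nM, a number that lies within the scatter of compound 2, so no order between these two can be stated. Compound 3 gives 10000 nM, a number beyond the scatter from compound 2.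

Compound 4, `N=C(N)c1cccc(C(=O)N[C@@H](C(=O)N2CCN(c3ccncc3)CC2)c2ccccc2)c1`, is not yet measured. It differs from compound 2 in one place: pyridin-4-yl in place of 4-fluorophenyl on an amine nitrogen in a ring. Going by the values given here, no pair of measured compounds differs in just this way, so there is no measured step to lean on. On the available numbers the change is expected to be small, with the step from compound 2 to compound 4 estimated at a 1.6-fold higher number from compound 2 to compound 4 (0.20 log units; within the scatter), within or close to the scatter. Compound 4 is therefore expected to give 2000 nM in this assay, with a range from 700 nM to 6000 nM.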

Compound 4, inhibition constant: 560 nM
The estimate for compound 4 lay 3.6-fold (0.55 log units) above the measured number; the measured number lies below the stated range.
By their numbers in this assay, from the lowest: compound 4; then compounds 2 and 1 (each within the scatter of the next); then compound 3.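

In this assay, pyridin-4-yl in place of 4-fluorophenyl on an amine nitrogen in a ring gives a 2.3-fold lower number from compound 2 to compound 4 (0.35 log units; beyond the scatter) and stands as a modest step. It shows that this position responds to the aromatic ring it carries, something compounds 1, 2 and 3 could not show, as no two of them differ in just one place. Nothing measured here explains the step.

Still open, going by these compounds, is whether the loss of the fluorine or the gain of the ring nitrogen matters, which a plain phenyl group at this position could separate. Pyridin-3-yl and pyridin-2-yl would test whether the place of that nitrogen within the ring counts, and it also remains open whether the step holds on other parts of the molecule.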